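Chromone dithiocarbamates: ring size at the thiocarbonyl nitrogen

The source may report more compounds than this note shows. Statements on the series, on what has been measured and on what is new or still open speak of the compounds shown alone.

Compound 1 `O=c1c(SC(=S)N2CCCCC2)coc2ccccc12`, compound 2 `O=c1c(Cl)c(CSC(=S)N2CCCCC2)oc2ccccc12` and compound 3 `O=c1c(Cl)c(CSC(=S)N2CCCC2)oc2ccccc12` have been measured; compound 4 `O=c1c(SC(=S)N2CCCC2)coc2ccccc12` has not. In a functional assay on HEp-2 cells (Homo sapiens) for antiproliferative activity, read by MTT assay, with a stated time of 72 h (on this read-out lower numbers stand for stronger inhibition and higher numbers for weaker inhibition), compound 1 gives 5800 nM, the highest of the three numbers and beyond the scatter from both others. In this assay compound 2 gives 940 nM and compound 3 gives 600 nM. The difference between the core of compound 1 and the core of compound 2 is not broken down here. Compound 2 and compound 3 differ in one place, (pyrrolidin-1-yl in place of piperidin-1-yl on a thiocarbonyl carbon), and the step of a 1.6-fold lower number from compound 2 to compound 3 (0.19 log units; within the scatter) lies within the scatter, so the ring size at the thiocarbonyl nitrogen made no clear difference on the chlorinated core. Compound 1 and compound 4 differ by the same change, (pyrrolidin-1-yl in place of piperidin-1-yl on a thiocarbonyl carbon), at a place described in the same words. Among the compounds with values here, only one measured example of this change exists, so the expectation for compound 4 is carried over from it. The expected step of a 1.6-fold lower number from compound 1 to compound 4 (0.21 log units; within the scatter) rests on a 1.6-fold lower number from compound 2 to compound 3 (0.19 log units; within the scatter), widened to allow for the weaker starting point of compound 1. Compound 4 is therefore expected to give about 3600 nM, between 1800 nM and 7500 nM.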

Compound 4, half-maximal inhibitory concentration: 7400 nM
Compound 4: middle estimate off by 2.1-fold (0.31 log units), on the low side, and the stated range covers the measured number.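

In this assay, the new step is a 1.3-fold higher number from compound 1 to compound 4 (0.11 log units; within the scatter), so pyrrolidin-1-yl in place of piperidin-1-yl on a thiocarbonyl carbon makes no clear difference on the core of compound 1 either. Set side by side, the two steps cannot be told apart, and on these two cores the change carries over as a step within the scatter: the same change on two cores in this assay, a 1.6-fold lower number (0.19 log units; within the scatter) from compound 2 to compound 3 and a 1.3-fold higher number (0.11 log units; within the scatter) from compound 1 to compound 4, 2.0-fold (0.30 log units) apart, within the scatter of two such steps

Within the data shown here, this shows only that the ring size at the thiocarbonyl nitrogen has no clear effect in these two pairs; it does not establish a direction for the change, since neither step can be read as a real rise or fall, and two pairs give no rule for other cores.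

Open, from the compounds shown here alone, is whether a morpholin-4-yl or diethylamino group on the thiocarbonyl carbon would give a step beyond the scatter on either core. Also open is which part of the difference between the core of compound 1 and the core of compound 2 accounts for the gap in their numbers.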